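This account rests on a few compounds, and the source may have more. Where it says the series, first, only, none or still open, it means among the compounds named here.

In an ADME assay on microsomes from liver (Mus musculus) for metabolic stability, read by LC-MS, with a stated time of 10 min (on this read-out higher numbers stand for a more stable compound and lower numbers for a less stable compound), compound 1 (`FC1(F)CCC(CN(C[C@H]2Cc3c(cccc3N3CCNCC3)CN2)[C@H]2CCCc3cccnc32)CC1`) gives 76.6%. Compound 3 (`CN(C[C@H]1Cc2c(cccc2N2CCN(c3cccc(C(F)(F)F)c3)CC2)CN1)[C@H]1CCCc2cccnc21`) gives 72.3%, within the scatter of compound 1. Compound 2 (`CN(C[C@H]1Cc2c(cccc2N2CCN3CCC[C@@H]3C2)CN1)[C@H]1CCCc2cccnc21`) gives 36.7%, lower than compound 1 by a margin beyond the scatter. Compound 4 (`CC(C)N(C[C@H]1Cc2c(cccc2N2CCNCC2)CN1)[C@H]1CCCc2cccnc21`) is the next to be read against compound 1, with one change: isopropyl in place of (4,4-difluorocyclohexyl)methyl on an amine nitrogen. For the measured compounds named here, no pair of measured compounds isolates this change, so the expectation is loose. In this assay, a moderate fall somewhat beyond the scatter is expected, and the expected step is a number 16.6 percentage points lower from compound 1 to compound 4 (beyond the scatter). The estimated value for compound 4 is 60%, with a range from 40% to 78%.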

Compound 4, percent of the compound remaining: 91%
For compound 4 the middle estimate is 31 percentage points below the measured one, and the stated range ends below it.
By their numbers in this assay, from the lowest: compound 2; then compounds 3 and 1 (each within the scatter of the next); then compound 4.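

In this assay, for the compounds shown here, isopropyl in place of (4,4-difluorocyclohexyl)methyl on an amine nitrogen gives a number 14.4 percentage points higher from compound 1 to compound 4 (beyond the scatter) as the first single-place step. This position therefore does not need the ring or the fluorine atoms for the compound to remain high on this read-out, and the much smaller isopropyl is the better of the two groups here. No measurement shown here explains the step. From the compounds shown here alone, whether the rise goes with losing the ring or losing the fluorine atoms stays open. A plain cyclohexylmethyl group on the same amine nitrogen would separate the two.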